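The compounds below may be only part of what the source reports. "The series", "measured", "known", "first", "only" and "open" are said of these compounds alone.

Values in an assay on HEK293 cells for inhibition of transient receptor potential cation channel subfamily M member 8 (Homo sapiens), read by FLIPR, with stated times of 5 min and 3 min; on this read-out lower numbers stand for stronger inhibition and higher numbers for weaker inhibition:
compound 1 `CCn1nnnc1-c1sc(-c2cccc(F)c2)nc1O`: compound 1 gives > 100000 nM, a limit of the assay and not a number.
compound 2 `CCn1nnc(-c2sc(-c3cccc(OC)c3)nc2O)n1`: compound 2 gives 245 nM.
compound 3 `CCON(C)C(=O)c1sc(-c2cccc(F)c2)nc1O`: compound 3 gives 1680 nM.

Compound 2 holds the lowest of the two numbers returned; the number for compound 3 is higher, and the gap lies beyond the scatter of repeated measurements. Compound 1 sits at the limit of > 100000 nM in this assay, at which 1 of the 3 values shown sits, so only a limit is known for it.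

The next compound in the series is compound 4 `CCn1nnc(-c2sc(-c3cccc(NC)c3)nc2O)n1`, still to be measured in this assay. It differs from compound 2 in one place: methylamino in place of methoxy on an aromatic carbon. Within the data shown here, no measured step of this kind stands, so the expectation rests on compound 2 alone. A change of this size is expected to move the number only a little, if at all, with a slight lean toward a weaker value.

Compound 4 is expected at 400 nM, with a range from 120 nM to 1300 nM. The estimated step of a 1.6-fold higher number from compound 2 to compound 4 (0.21 log units; within the scatter) is expected to stay within the scatter.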

Compound 4, half-maximal inhibitory concentration: 1020 nM
Compound 4: middle estimate off by 2.6-fold (0.41 log units), on the low side; measured number inside the range.
By their numbers in this assay, from the lowest: compound 2; then compounds 4 and 3 (each within the scatter of the next). At a limit, above all of these: compound 1.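

In this assay, the position on the six-membered aromatic ring, meta to a large group, now has its first measured step: methylamino in place of methoxy gives a 4.2-fold higher number from compound 2 to compound 4 (0.62 log units; beyond the scatter). The position therefore responds to an exchange of two groups with the same heavy-atom count, and the exchange also adds one hydrogen-bond donor, so the direction here favours methoxy over methylamino, on this single pair only. No measurement shown accounts for this step.

As far as these compounds go, whether the step follows the entering hydrogen-bond donor or the swap of oxygen for nitrogen stays open, since the two travel together in this pair. A dimethylamino or ethoxy group at this place would bear on that question, and a hydroxyl or a plain amine would extend the comparison.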